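The compounds below may be only part of what the source reports. "The series", "measured", "known", "first", "only" and "open" are said of these compounds alone.

Measured compounds:
compound 1, `O=C(Nc1ccc(C(=O)N2CCCN(Cc3ccccc3)c3sccc32)cc1)c1ccccc1-c1ccccc1` — 70 nM
compound 2, `CN1CCN(CCCCOc2cc(C(=O)N3CCCCc4sccc43)ccc2NC(=O)c2ccccc2-c2ccccc2)CC1` — 7 nM
compound 3, `COc1cc(C(=O)N2CCCC(N(C)C)c3sccc32)ccc1NC(=O)c1ccccc1-c1ccccc1` — 10 nM

The three were tested in an assay on adrenal medulla for inhibition of Vasopressin V2 receptor (Rattus norvegicus), read by radioligand binding; on this read-out lower numbers stand for stronger inhibition and higher numbers for weaker inhibition. Compound 2 gives the lowest of the three numbers, but compound 3 sits within the usual scatter of it, so no order between those two can be claimed; only compound 1 stands clearly apart with its higher number. Compound 4, `CN1CCCN(CCCOc2cc(C(=O)N3CCCCc4sccc43)ccc2NC(=O)c2ccccc2-c2ccccc2)CC1`, is built from the same atoms as compound 2 joined differently: 4-methyl-1,4-diazepan-1-yl in place of (4-methylpiperazin-1-yl)methyl on a saturated chain carbon, three bonds along the chain from an oxygen on an aromatic ring. Among the measured compounds shown here, nothing measured so far speaks to this kind of rearrangement, so any step from compound 2 to compound 4 in this assay is expected to stay within the scatter, in no particular direction. Compound 4 is therefore estimated at 9 nM, with a range from 3 nM to 27 nM, a step of a 1.3-fold higher number from compound 2 to compound 4 (0.11 log units; within the scatter).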

Compound 4, half-maximal inhibitory concentration: < 1 nM
Compound 4 was reported as a limit (the forecaster's own chance of this, stated with the estimate: 2%); middle value at least 9.0-fold (0.95 log units) from the limit.
By their numbers in this assay, from the lowest: compounds 2 and 3 (each within the scatter of the next); then compound 1. At a limit, below all of these: compound 4.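

In this assay, 4-methyl-1,4-diazepan-1-yl in place of (4-methylpiperazin-1-yl)methyl on this saturated chain carbon gives an at least 7.0-fold lower number from compound 2 to compound 4 (0.84 log units; beyond the scatter). Among the compounds shown here, this shows what the earlier compounds could not: rejoining the same atoms at this position moves the number beyond the scatter. Compound 4 gives < 1 nM, which is a limit, so the step has no upper size: the limit of < 1 nM in this assay, at which 1 of the 4 values shown sits.

The compounds shown leave open whether the seven-membered ring or the shorter chain carries the step. A 3-(4-methylpiperazin-1-yl)propyl group on the same oxygen would separate the two.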